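This account rests on a few compounds, and the source may have more. Where it says the series, first, only, none or still open, it means among the compounds named here.

The series shares one core, seen in compound 1 `COc1cc(-c2nn(-c3cccc(NC(=O)Nc4cc(C(F)(F)F)cc(C(F)(F)F)c4)c3)cc2-c2ccncc2)ccc1Cl`, compound 2 `COc1cc(-c2nn(-c3cccc(NC(=O)c4cccc(C(F)(F)F)c4)c3)cc2-c2ccncc2)ccc1Cl` and compound 3 `O=C(Nc1cccc(-n2cc(-c3ccncc3)c(-c3ccc(Cl)c(O)c3)n2)c1)Nc1cc(C(F)(F)F)cc(C(F)(F)F)c1`. In a functional assay on IGROV-1 cells (Homo sapiens) for inhibition, read by sulforhodamine B assay, with a stated time of 48 h (on this read-out lower numbers stand for higher toxicity in this test and higher numbers for lower toxicity in this test), compound 1 gives 23700 nM. Compound 3 gives 38200 nM in this assay, and the step of a 1.6-fold higher number from compound 1 to compound 3 (0.21 log units; within the scatter) shows how little the hydrogen in place of methyl on the ring oxygen alters the read-out. Compound 2 stands apart from both: in this assay compound 2 reaches only > 50000 nM, which is a limit of the test and not a number, as shown by the limit of > 50000 nM in this assay, at which 1 of the 3 values shown sits. Compound 4 `COc1cc(-c2nn(-c3cccc(NC(=O)Nc4ccc(Cl)c(C(F)(F)F)c4)c3)cc2-c2ccncc2)ccc1Cl` has not yet been measured. It differs from compound 2 by (4-chloro-3-(trifluoromethyl)phenyl)amino in place of 3-(trifluoromethyl)phenyl on a carbonyl carbon. For the measured compounds named here, the single measured step, a 1.6-fold higher number from compound 1 to compound 3 (0.21 log units; within the scatter), concerns a different part of the molecule and lies within the scatter, so it offers no direct guide to a change at the carbonyl; what remains is that compound 1, which also carries an amino group on its carbonyl carbon, gives 23700 nM, a numbered value rather than a limit. Compound 4 is therefore expected to land near the level of compound 1, and the step of an at least 2.0-fold lower number from compound 2 to compound 4 (0.30 log units; that floor lies within the scatter) is expected to run toward a measurable value. The estimate for compound 4 in this assay is 25000 nM, with a range from 10000 nM to 60000 nM.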

Compound 4, concentration lethal to 50% of the cells: > 32500 nM
Compound 4 was reported as a limit; the forecaster's own chance of this, stated with the estimate: 25%; middle value at least 1.3-fold (0.11 log units) away from the limit.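

In this assay compound 4 gives > 32500 nM, which is a limit of the test and not a number. For the compounds shown here, compound 2 gives > 50000 nM, also a limit, so no step between compound 2 and compound 4 can be read. The compounds shown leave open whether (4-chloro-3-(trifluoromethyl)phenyl)amino in place of 3-(trifluoromethyl)phenyl on a carbonyl carbon changes the read-out at all, and in which direction.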